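Predicting an aryl amide on the methoxy core

The compounds below may be only part of what the source reports. "The series", "measured", "known", "first", "only" and "open" are said of these compounds alone.

Measured so far in a functional assay on HeLa cells (Homo sapiens) for inhibition, read by MTT assay, with a stated time of 48 h; on this read-out lower numbers stand for stronger inhibition and higher numbers for weaker inhibition:
compound 1 `COc1ccc2c(=O)c(/C=C/C(=O)NCc3cccc(F)c3)coc2c1` gives 17600 nM
compound 2 `Cc1ccccc1NC(=O)/C=C/c1coc2cc(O)ccc2c1=O` gives 8670 nM
compound 3 `O=C(/C=C/c1coc2cc(O)ccc2c1=O)Nc1ccccc1` gives 9700 nM

Among the three compounds measured, compound 1 has the highest number, so it is the weakest inhibitor here; it stands closest to compound 3, and the gap to compound 2 is just beyond the scatter. Compound 4 `COc1ccc2c(=O)c(/C=C/C(=O)Nc3ccc(C)cc3)coc2c1` is an unmeasured partner of compound 1. The change is 4-methylphenyl in place of 3-fluorobenzyl on an amide-type nitrogen.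

Among the measured compounds shown here, only one measured step exists, and it concerns a different change: a 1.1-fold higher number from compound 2 to compound 3 (0.05 log units; within the scatter), which is within the scatter. Compounds 2 and 3 both carry an aromatic ring directly on the amide-type nitrogen, as compound 4 does, but they differ from compound 1 in more than one place, so their values cannot be read as a direct guide to the step from compound 1 to compound 4. What they do show is that the two compounds with an aryl group on the amide-type nitrogen sit below compound 1. The estimated step is therefore a 1.5-fold lower number from compound 1 to compound 4 (0.17 log units; within the scatter), a modest move toward lower numbers that carries wide uncertainty. The estimate for compound 4 is 12000 nM, with a range from 5000 nM to 30000 nM.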

Compound 4, half-maximal inhibitory concentration: 24100 nM
Beside the measured number, compound 4's estimate is 2.0-fold (0.30 log units) below it; measured number inside the range.
By their numbers in this assay, from the lowest: compounds 2, 3, 1 and 4 (each within the scatter of the next, the first and the last beyond it).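

In this assay, among the compounds shown here, the swap of 3-fluorobenzyl for 4-methylphenyl on the amide-type nitrogen gives a 1.4-fold higher number from compound 1 to compound 4 (0.14 log units; within the scatter), the first direct reading of a change at this nitrogen, since the only earlier step concerned a methyl group on an aromatic carbon. On the core of compound 1, this nitrogen therefore accepts either group with no shift beyond the usual scatter of repeated measurements, even though the swap removes the fluorine, adds a methyl group and leaves one heavy atom fewer in the group. No evidence is available on why the two numbers stand so close.

Since these differences arrive together in a single step, the compounds shown cannot tell whether each one alone has little effect on the number or whether separate effects happen to offset each other. They also leave open whether a larger departure at the same nitrogen, such as a longer chain like 3-phenylpropyl or a carboxylic acid or an amine on the aromatic ring, would give a step beyond the scatter.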